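This account rests on a few compounds, and the source may have more. Where it says the series, first, only, none or still open, it means among the compounds named here.

Of the compounds shown here, two have been measured in a functional assay on HEK293 cells for agonist activity at Free fatty acid receptor 1 (Homo sapiens), read by fluorescence and calcium flux, with a stated time of 10 min; a lower number here means that less compound is needed, a higher number that more compound is needed for the effect. Compound 1 `O=C(O)CCc1ccc(NCC2COc3ccc(Cl)cc3O2)cc1F` gives 13600 nM in this assay. Compound 2 `CC#C[C@@H](CC(=O)O)c1ccc(OC[C@H]2COc3ccc(F)cc3O2)cc1` gives 210 nM, the lowest of the two numbers, and its gap to compound 1 lies beyond the usual scatter. Compound 3 `CC#C[C@@H](CC(=O)O)c1ccc(OC[C@H]2COc3ccc(OC(F)(F)F)cc3O2)cc1` keeps the core of compound 2 and differs in one place: trifluoromethoxy in place of fluoro on an aromatic carbon. For the measured compounds named here, no measured pair shows a step of this kind, so only a small step is expected, at most a slight rise in the number. For compound 3 the expected value is 300 nM, within 100 nM to 900 nM. That amounts to an expected step of a 1.4-fold higher number from compound 2 to compound 3 (0.15 log units; within the scatter).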

Compound 3, half-maximal effective concentration: 700 nM
For compound 3 the middle estimate is 2.3-fold (0.37 log units) below the measured one; measured number inside the range.
By their numbers in this assay, from the lowest: compound 2; then compound 3; then compound 1.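

At this position on the aromatic ring, replacing fluoro with the larger trifluoromethoxy group gives a 3.3-fold higher number from compound 2 to compound 3 (0.52 log units; beyond the scatter) in this assay, so this change costs some potency, although the step is modest. For the compounds shown here, the result therefore shows that the position is sensitive to which group it carries, and that five heavy atoms there still leave a number well short of the one for compound 1, which differs in more than one place. No available evidence explains the rise. The compounds shown leave open how a methoxy group or a nitrile would behave on this same carbon. They also leave open whether the same swap would give a similar step on another core.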